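The compounds below may be only part of what the source reports. "The series", "measured", "known", "first", "only" and "open" are said of these compounds alone.

Measured so far in a functional assay on Jurkat cells (Homo sapiens); a lower number here means a stronger inhibitor, a higher number a weaker inhibitor:
compound 1, `CC(C)[C@H](NC(=O)COc1cccc2ccccc12)C(=O)N[C@@H](CC(=O)O)C(=O)COc1ccc(-c2ccccc2)cc1`: 87900 nM
compound 2, `CC(C)[C@H](NC(=O)COc1cccc2ccccc12)C(=O)N[C@@H](CC(=O)O)C(=O)COc1ccc(Oc2ccccc2)cc1`: 12700 nM
compound 3, `CC(C)[C@H](NC(=O)COc1cccc2ccccc12)C(=O)N[C@@H](CC(=O)O)C(=O)COc1ccc([N+](=O)[O-])cc1`: > 100000 nM

The value of compound 3 is a limit of this assay and not a number (the limit of > 100000 nM in this assay, at which 1 of the 3 values shown sits). On the numbers shown, compound 3 stands at the weak end together with compound 1, the pair not separated beyond the scatter: an at least 1.1-fold higher number from compound 1 to compound 3 (0.05 log units; that floor lies within the scatter). From compound 2 the move was an at least 7.8-fold higher number from compound 2 to compound 3 (0.89 log units; beyond the scatter), and from compound 1 to compound 2 the phenoxy change gave a 6.9-fold lower number from compound 1 to compound 2 (0.84 log units; beyond the scatter).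

Compound 4, `CC(C)[C@H](NC(=O)COc1cccc2ccccc12)C(=O)N[C@@H](CC(=O)O)C(=O)COc1cccc(C(F)(F)F)c1F`, carries the change (2-fluoro-3-(trifluoromethyl)phenyl in place of 4-nitrophenyl on an oxygen on a saturated carbon). Going by the values given here, none of the measured steps places this entering group; the steps to hand only show that phenoxy gives a lower number than either phenyl or nitro, while phenyl and nitro sit together at the weak end. Compound 4 is therefore expected to move only by an at least 1.6-fold lower number from compound 3 to compound 4 (0.22 log units; that floor lies within the scatter) in this assay, with the direction left open by the data. Compound 4 is estimated at 60000 nM, within a range from 15000 nM to 200000 nM, and a limit rather than a number remains a real possibility.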

Compound 4, half-maximal inhibitory concentration: 50400 nM
For compound 4 the middle estimate is 1.2-fold (0.08 log units) above the measured one; the range from low to high includes it.
By their numbers in this assay, from the lowest: compound 2; then compounds 4 and 1 (each within the scatter of the next). At a limit, above all of these: compound 3.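

In this assay, compound 4 shows that a single six-membered aromatic ring, without the second ring carried by compounds 1 and 2, can give a measured number at this position, on an oxygen on a saturated carbon. The value of compound 3 is a limit of the assay and not a number: the limit of > 100000 nM in this assay, at which 1 of the 4 values shown sits. The change gives an at least 1.9-fold lower number from compound 3 to compound 4 (0.29 log units; that floor lies within the scatter), and against the 4-phenylphenyl group it gives a 1.7-fold lower number from compound 1 to compound 4 (0.24 log units; within the scatter), leaving 2-fluoro-3-(trifluoromethyl)phenyl and 4-phenylphenyl not separated in this assay.

The separate shares of the fluorine and the trifluoromethyl group remain open, as neither stands alone on the ring in the compounds shown. Also open, from the compounds shown here alone, is what an amine or a carboxylic acid on this aromatic ring would do to the number.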